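The source may hold more compounds than are shown below. What is called first, only, known or untested is meant among the compounds shown, and "the series" means these compounds.

Compound 3 `COc1ccc(C(=O)/C=C/c2cc(-c3cc(OC)c(OC)c(OC)c3)n[nH]2)cc1OC` stands lowest of the three numbers in a functional assay on MDA-MB-435 cells (Homo sapiens) for cytotoxicity, read by sulforhodamine B assay, with a stated time of 48 h, tested at 1 uM; a lower number here means a stronger effect, a higher number a weaker effect of the compound at the concentration tested: compound 3 gives 70%, while compound 1 `COc1cc(-c2cc(/C=C/C(=O)c3ccc(N)cc3)[nH]n2)cc(OC)c1OC` gives 88% and compound 2 `COc1cc(-c2cc(/C=C/C(=O)c3ccc(Cl)c(Cl)c3)[nH]n2)cc(OC)c1OC` gives 90%. Compound 4 `COc1cc(-c2cc(/C=C/C(=O)c3ccc(F)c(F)c3)[nH]n2)cc(OC)c1OC` differs from compound 3 in a single place: 3,4-difluorophenyl in place of 3,4-dimethoxyphenyl on a carbonyl carbon. Going by the values given here, the steps that bear on this are a number 20 percentage points lower from compound 2 to compound 3 (beyond the scatter) and a number 18 percentage points lower from compound 1 to compound 3 (beyond the scatter), both modest and beyond the scatter, whereas a number 2 percentage points higher from compound 1 to compound 2 (within the scatter) stayed within it. The change into compound 4 reverses the kind of exchange that produced the step into compound 3, so a step of similar size in the upward direction is expected, a number 18 percentage points higher from compound 3 to compound 4 (beyond the scatter). Compound 4 is therefore estimated to give 88%, within a range from 76% to 98%.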

Compound 4, a percentage reported as activity, at one concentration (the size of the read-out at that concentration, not a potency): 88%
Compound 4: the middle estimate sits on the measured number at the digits printed; the range from low to high includes it.
By their numbers in this assay, from the lowest: compound 3; then compounds 1, 4 and 2 (each within the scatter of the next).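

In this assay, placing 3,4-difluorophenyl instead of 3,4-dimethoxyphenyl on the carbonyl carbon gives a number 18 percentage points higher from compound 3 to compound 4 (beyond the scatter), whereas the comparisons with the other two aryl groups give a number 2 percentage points lower from compound 2 to compound 4 (within the scatter) and no change at the digits printed from compound 1 to compound 4 (within the scatter). Among these four compounds, only the 3,4-dimethoxyphenyl of compound 3 therefore stands apart at this position, while the 3,4-difluorophenyl, 3,4-dichlorophenyl and 4-aminophenyl compounds cannot be told apart. Nothing available explains this difference. Going by these compounds, it remains open whether the lower number needs both methoxy groups, and whether a single methoxy, an ethoxy or a hydroxy group on the phenyl ring would preserve it.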